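The compounds below may be only part of what the source reports. "The series", "measured", "known", "first", "only" and "open" are said of these compounds alone.

In a functional assay on SK-BR-3 cells (Homo sapiens) for inhibition, read by CellTiter-Glo, with a stated time of 72 h (on this read-out lower numbers stand for stronger inhibition and higher numbers for weaker inhibition), compound 1 `CC(C)c1nn(-c2ccc(C(N)=O)c(N[C@H]3CC[C@H](O)CC3)c2)c2nccc(-n3cnc(-c4ccncc4)c3)c12` gives 165 nM while compound 2 `CC(C)c1nn(-c2ccc(C(N)=O)c(N[C@H]3CC[C@H](O)CC3)c2)c2nccc(-n3cnc(-c4cncnc4)c3)c12` gives 387 nM and compound 3 `CC(C)c1nn(-c2ccc(C(N)=O)c(N[C@H]3CC[C@H](O)CC3)c2)c2nccc(-n3cnc(-c4ccccc4)c3)c12` gives 276 nM as its reading. Compound 3 thus stands within the scatter of both others. Compound 4 `CC(C)c1nn(-c2ccc(C(N)=O)c(N[C@H]3CC[C@H](O)CC3)c2)c2nccc(-c3ccsc3)c12` carries thiophen-3-yl in place of 4-phenyl-1H-imidazol-1-yl on an aromatic carbon and is otherwise the same as compound 3. The measured steps bear on this only loosely, as each swaps just the outermost ring of the group that now leaves. Pyrimidin-5-yl in place of pyridin-4-yl gives a 2.3-fold higher number from compound 1 to compound 2 (0.37 log units; beyond the scatter) and is modest. Phenyl in place of pyridin-4-yl gives a 1.7-fold higher number from compound 1 to compound 3 (0.22 log units; within the scatter) and phenyl in place of pyrimidin-5-yl gives a 1.4-fold lower number from compound 2 to compound 3 (0.15 log units; within the scatter) as the other two steps. Within the data shown here, no measured compound lacks the whole group, so the direction is tentative and the range is wide. The expected change is a 2.5-fold higher number from compound 3 to compound 4 (0.40 log units; beyond the scatter) toward weaker inhibition. For compound 4 the estimate is 700 nM as a middle value, with an expected range from 150 nM to 3000 nM in this assay.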

Compound 4, half-maximal inhibitory concentration: > 10000 nM
Compound 4: a limit, no number (the forecaster's own chance of this, stated with the estimate: 5%); middle value at least 14-fold (1.15 log units) away from the limit.
By their numbers in this assay, from the lowest: compounds 1, 3 and 2 (each within the scatter of the next, the first and the last beyond it). At a limit, above all of these: compound 4.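

In this assay compound 4 gives no number, only a limit, > 10000 nM. Changing the outermost ring alone moved the readings only modestly or within the scatter, but replacing the whole group at this position, an aromatic carbon opposite the ring nitrogen, with thiophen-3-yl costs far more: it gives an at least 36-fold higher number from compound 3 to compound 4 (1.55 log units; beyond the scatter), an at least 25-fold higher number from compound 2 to compound 4 (1.41 log units; beyond the scatter) and an at least 60-fold higher number from compound 1 to compound 4 (1.78 log units; beyond the scatter). Among these four compounds, then, the three with a measured number all carry a 1H-imidazol-1-yl ring bearing a second ring, while the one with a single thiophen-3-yl ring reaches the limit.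

From the compounds shown here alone, what stays open is whether the loss follows from removing the outer ring, from replacing the imidazole ring, or from both. A plain 1H-imidazol-1-yl group or a lone phenyl ring at this carbon would help separate these possibilities.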